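Nitro in place of bromo on the anilide ring

The compounds below may be only part of what the source reports. "The series", "measured", "known", "first", "only" and "open" are said of these compounds alone.

Three compounds share one core and differ only in the aryl group on the amide-type nitrogen. Compound 1 `O=C(CSc1nc(Nc2ccccc2)c2ccccc2n1)Nc1ccccc1F` gives in a functional assay on PC-3 cells (Homo sapiens) for inhibition, read by MTT assay, with a stated time of 72 h (a lower number here means a stronger inhibitor, a higher number a weaker inhibitor), a value of 12400 nM. Compound 2 `O=C(CSc1nc(Nc2ccccc2)c2ccccc2n1)Nc1cccc(F)c1` gives in this assay a value of 15600 nM, and compound 3 `O=C(CSc1nc(Nc2ccccc2)c2ccccc2n1)Nc1cccc(Br)c1` gives in this assay a value of 11400 nM. Compound 3 holds the lowest of the three numbers, but its nearest neighbour compound 1 lies within the scatter, as the step of a 1.1-fold lower number from compound 1 to compound 3 (0.04 log units; within the scatter) shows, and the step of a 1.4-fold lower number from compound 2 to compound 3 (0.14 log units; within the scatter) is likewise within the scatter. Compound 4 `O=C(CSc1nc(Nc2ccccc2)c2ccccc2n1)Nc1cccc([N+](=O)[O-])c1` differs from compound 3 by nitro in place of bromo on an aromatic carbon. The step that bears most closely on this is a 1.4-fold lower number from compound 2 to compound 3 (0.14 log units; within the scatter), a swap of one substituent on the same aromatic carbon that moved nothing beyond the scatter; the step of a 1.3-fold higher number from compound 1 to compound 2 (0.10 log units; within the scatter) was equally flat. For the measured compounds named here, no step involving a nitro group has been measured. He therefore expects no step beyond the scatter for compound 4, a 1.1-fold higher number from compound 3 to compound 4 (0.02 log units; within the scatter). Compound 4 is estimated at 12000 nM in this assay, with a range from 5000 nM to 30000 nM.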

Compound 4, half-maximal inhibitory concentration: 11800 nM
For compound 4 the middle estimate is 1.0-fold (0.01 log units) above the measured one; the range from low to high includes it.
By their numbers in this assay, from the lowest: compounds 3, 4, 1 and 2 (each within the scatter of the next).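

In this assay nitro, with three heavy atoms and two hydrogen-bond acceptors, takes the place of bromo, with one heavy atom and no hydrogen-bond acceptors, and the number stays flat (a 1.0-fold higher number from compound 3 to compound 4 (0.01 log units; within the scatter)). The nitro compound also stays within the scatter of both fluoro compounds (a 1.3-fold lower number from compound 2 to compound 4 (0.12 log units; within the scatter); a 1.1-fold lower number from compound 1 to compound 4 (0.02 log units; within the scatter)), so all four aryl groups shown on the amide-type nitrogen read alike, and this position has yet to show a step beyond the scatter. Nothing available here accounts for this flat reading.

From the compounds shown here alone, whether a carboxylic acid or an amine on the same aromatic carbon would stay within the scatter remains open. So does the effect of a longer chain in place of the link that carries the amide.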